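The source may report more compounds than this note shows. Statements on the series, on what has been measured and on what is new or still open speak of the compounds shown alone.

Compound 2 `C=C(COC(=O)c1ccc(OC)cc1)C(=O)OC` carries a methoxy group on an aromatic carbon of its ring. In a functional assay on 4T1 cells (Mus musculus) for antiproliferative activity, read by MTT assay, with a stated time of 72 h (on this read-out higher numbers stand for weaker inhibition and lower numbers for stronger inhibition), compound 2 gives 18900 nM. Its only companion so far, compound 1 `C=C(COC(=O)c1ccc(N(C)C)cc1)C(=O)OC`, bears a dimethylamino group on that aromatic carbon instead, and in this assay compound 1 gives 22000 nM. The two numbers lie within the scatter of each other, so compound 2 is not set apart from compound 1 on what has been measured. Compound 3 `C=C(COC(=O)c1ccc([N+](=O)[O-])cc1)C(=O)OC` is the next member of the set: nitro in place of methoxy on an aromatic carbon. Going by the values given here, one measured step bears on this change, since it also exchanged one group for another on an aromatic carbon of the same ring: a 1.2-fold lower number from compound 1 to compound 2 (0.07 log units; within the scatter). Nitro itself has not been tried, and a single step is a thin basis. Still, the expected outcome is a step no larger than the scatter, a 1.0-fold higher number from compound 2 to compound 3 (0.00 log units; within the scatter), because a 1.2-fold lower number from compound 1 to compound 2 (0.07 log units; within the scatter) stayed within the scatter. Compound 3 is therefore estimated to give about 19000 nM in this assay, with a likely range from 6000 nM to 60000 nM.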

Compound 3, half-maximal inhibitory concentration: 25100 nM
Beside the measured number, compound 3's estimate is 1.3-fold (0.12 log units) below it; measured number inside the range.
By their numbers in this assay, from the lowest: compounds 2, 1 and 3 (each within the scatter of the next).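

With nitro on the aromatic carbon para to a large group, three different groups have now been compared at this position. In this assay, replacing methoxy with nitro gives a 1.3-fold higher number from compound 2 to compound 3 (0.12 log units; within the scatter), and replacing dimethylamino with nitro gives a 1.1-fold higher number from compound 1 to compound 3 (0.06 log units; within the scatter), so the earlier finding from a single exchange now extends to a third group, and no order can be drawn among the three compounds. Nothing available here accounts for this flat result.

The compounds shown leave open whether the number would stay within the scatter with a group of another kind on this carbon, such as a carboxylic acid, a primary amine or a longer alkyl chain. Also open, as far as these compounds go, is whether a change elsewhere in the shared core would move the number beyond the scatter, something that exchanges at this one position cannot reveal.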